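A few compounds are considered here, and "the series" means these few. Any claim that something is new, unique, unknown or untested is made for them only; others in the source may bear on it.

Measured so far in an ADME assay on MRC5 cells (Homo sapiens), read by MTT assay, with a stated time of 72 h (on this read-out higher numbers stand for weaker inhibition and lower numbers for stronger inhibition), are three compounds:
- Compound 1 `CNc1ncnc2c1c(-c1ccoc1)cn2[C@@H]1O[C@H](CO)[C@@H](O)[C@H]1O` gives > 100000 nM here
- Compound 2 `Cc1ncnc2c1c(-c1ccsc1)cn2[C@@H]1O[C@H](CO)[C@@H](O)[C@H]1O` gives > 100000 nM here
- Compound 3 `COc1nc(N)nc2c1c(-c1ccoc1)cn2[C@@H]1O[C@H](CO)[C@@H](O)[C@H]1O` gives > 100000 nM here

Each of these values is a limit of the assay and not a number. Compound 3 therefore has no exact position, and it shares with compound 1 and compound 2 the same the limit of > 100000 nM in this assay, at which 3 of the 3 values shown sit, mark. Compound 4 `COc1nc(N)nc2c1c(-c1cc3ccccc3o1)cn2[C@@H]1O[C@H](CO)[C@@H](O)[C@H]1O` carries 1-benzofuran-2-yl in place of furan-3-yl on an aromatic carbon and keeps the rest of compound 3 unchanged. Among the compounds with values here, no measured step between compounds guides the expectation. The expected change is an at least 1.6-fold lower number from compound 3 to compound 4 (0.22 log units; that floor lies within the scatter) as an estimate, at most a modest move toward stronger inhibition. In this assay compound 4 is estimated at 60000 nM with an expected range of 15000 nM to 100000 nM for now.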

Compound 4, half-maximal inhibitory concentration: 22700 nM
For compound 4 the middle estimate is 2.6-fold (0.42 log units) above the measured one; the range from low to high includes it.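

In this assay, the group on this aromatic carbon of the five-membered ring can change the read-out: 1-benzofuran-2-yl in place of furan-3-yl gives an at least 4.4-fold lower number from compound 3 to compound 4 (0.64 log units; beyond the scatter). On these data alone, compound 3 has only a limit, so this step is a minimum and its full size stays unknown. Compound 4 is the only compound shown with an exact value: the limit of > 100000 nM in this assay, at which 3 of the 4 values shown sit.

As far as these compounds go, it remains open whether the added six-membered aromatic ring or the different attachment point of the furan ring matters more. From the compounds shown here alone, how furan-2-yl, phenyl or an amine at this place would read also remains open.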